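A few compounds are considered here, and "the series" means these few. Any claim that something is new, unique, unknown or untested is made for them only; others in the source may bear on it.

Compound 1 `COc1ccc(Cl)cc1C(C)NC(=O)NS(=O)(=O)c1ccc(Cl)cc1` sits at a limit in a functional assay on thoracic aorta (Rattus norvegicus, strain Wistar), with a stated time of 15 min (a higher number here means that more compound is needed for the effect, a lower number that less compound is needed), so > 300000 nM is a limit and not a number. This is the limit of > 300000 nM in this assay, at which 1 of the 2 values shown sits. Compound 2 `COc1ccc(Br)cc1C(C)NC(=O)NS(=O)(=O)c1ccc(Cl)cc1` gives 80900 nM in this assay. For the measured compounds named here, the only measured step, bromo in place of chloro on an aromatic carbon, is an at least 3.7-fold lower number from compound 1 to compound 2 (0.56 log units; beyond the scatter). Compound 3 `COc1ccc(Cl)cc1C(C)NC(=O)NS(=O)(=O)c1ccc(C)cc1` has methyl in place of chloro on an aromatic carbon, the change being (methyl in place of chloro on an aromatic carbon). That carbon lies para to a large group and is not the carbon altered in the measured step, so that step bears on the new change only loosely. No clear step in either direction is therefore expected in this assay, and the assay may again report only a limit. The expected step is an at least 1.2-fold lower number from compound 1 to compound 3 (0.07 log units; that floor lies within the scatter). For compound 3 the estimated value is 250000 nM, within an expected range of 80000 nM to 600000 nM.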

Compound 3, half-maximal effective concentration: > 300000 nM
Compound 3: only a limit was reported; the forecaster's own chance of this, stated with the estimate: 60%; middle value at least 1.2-fold (0.07 log units) away from the limit.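

Compound 3 gives only a limit in this assay, > 300000 nM, and with compound 1 also at a limit, no step between compound 1 and compound 3 can be read: the limit of > 300000 nM in this assay, at which 2 of the 3 values shown sit.

The compounds shown leave open whether 4-methylphenyl in place of 4-chlorophenyl changes the number in this assay at all.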